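Piperidin-1-yl in place of butylamino on a carbonyl carbon

The source may report more compounds than this note shows. Statements on the series, on what has been measured and on what is new or still open speak of the compounds shown alone.

In a functional assay on U-937 cells (Homo sapiens) for antiproliferative activity, read by MTT assay, with a stated time of 24 h (a higher number here means a weaker inhibitor, a lower number a stronger inhibitor), compound 1 (`CCCCNC(=O)COc1ccc(C(=O)c2c(CCCC)oc3ccccc23)cc1`) gives 22800 nM, compound 2 (`CCCCc1oc2ccccc2c1C(=O)c1ccc(OCC(=O)NCc2ccccc2)cc1`) gives 16300 nM and compound 3 (`CCCCNC(=O)CCCOc1ccc(C(=O)c2c(CCCC)oc3ccccc23)cc1`) gives 24600 nM. Compound 3 thus stands level with both others, within the scatter. Compound 4 (`CCCCc1oc2ccccc2c1C(=O)c1ccc(OCCCC(=O)N2CCCCC2)cc1`) carries piperidin-1-yl in place of butylamino on a carbonyl carbon. Going by the values given here, no measured compound carries this ring, so the data leave that exact change untested. The nearest evidence is small: a 1.4-fold lower number from compound 1 to compound 2 (0.15 log units; within the scatter), a 1.1-fold higher number from compound 1 to compound 3 (0.03 log units; within the scatter) and a 1.5-fold higher number from compound 2 to compound 3 (0.18 log units; within the scatter). With these steps so small, no shift beyond the scatter is expected, and the expected step is a 1.1-fold lower number from compound 3 to compound 4 (0.05 log units; within the scatter). Compound 4 is estimated at 22000 nM, within an expected range of 11000 nM to 45000 nM.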

Compound 4, half-maximal inhibitory concentration: 16600 nM
Beside the measured number, compound 4's estimate is 1.3-fold (0.12 log units) above it, and the stated range covers the measured number.
By their numbers in this assay, from the lowest: compounds 2, 4, 1 and 3 (each within the scatter of the next).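

In this assay, piperidin-1-yl in place of butylamino on the carbonyl carbon, which closes a six-membered ring and gives up the amide hydrogen, yields a 1.5-fold lower number from compound 3 to compound 4 (0.17 log units; within the scatter) and so moves nothing measurable. Compound 4 also stands level with the two other compounds, with a 1.0-fold higher number from compound 2 to compound 4 (0.01 log units; within the scatter) and a 1.4-fold lower number from compound 1 to compound 4 (0.14 log units; within the scatter) as the printed steps. Among these four compounds, then, a ring at this amide nitrogen reads the same as the open chains, and no measurement at hand explains this.

Still open, from the compounds shown here alone, is whether a morpholine ring, an amine or a carboxylic acid at this carbonyl carbon would shift the number beyond the scatter.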